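The source may hold more compounds than are shown below. What is called first, only, known or untested is meant among the compounds shown, and "the series" means these compounds.

Working notes on the series. In a functional assay on MGC-803 cells (Homo sapiens) for antiproliferative activity, read by MTT assay, with a stated time of 72 h (on this read-out higher numbers stand for weaker inhibition and lower numbers for stronger inhibition), compound 1 `O=C(COc1ccc(C(=O)/C=C/c2ccc(Cl)cc2Cl)cc1)N[C@H]1CCOC1=O` gives 26500 nM. Compound 3 `COc1ccccc1/C=C/C(=O)c1ccc(OCC(=O)N[C@H]2CCOC2=O)cc1` gives 39400 nM in this assay; the step of a 1.5-fold higher number from compound 1 to compound 3 (0.17 log units; within the scatter) concerns a side group on the shared core of that pair and is within the scatter. Compound 2 `O=C1OCC[C@@H]1NC(=S)SCCOc1ccc([N+](=O)[O-])cc1` reaches only > 100000 nM in this assay, which is a limit of the assay and not a number. On the numbers shown compound 2 thus stands at the top, as described by the limit of > 100000 nM in this assay, at which 1 of the 3 values shown sits. Compound 4 `O=C1OCC[C@@H]1NC(=S)SCCOc1ccccc1` differs from compound 2 by hydrogen in place of nitro on an aromatic carbon. Among the measured compounds shown here, no measured step covers this change; the only one, a 1.5-fold higher number from compound 1 to compound 3 (0.17 log units; within the scatter), belongs to a different core and is itself within the scatter. No step beyond the scatter in this assay is expected. Compound 4 is therefore estimated at 100000 nM, with a range from 40000 nM to 250000 nM. The expected step is a number no higher from compound 2 to compound 4 (the limit leaves the size open), and a limit rather than a number remains likely.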

Compound 4, half-maximal inhibitory concentration: 53800 nM
Estimate against measurement, compound 4: 1.9-fold (0.27 log units) above, within the range that was stated.
By their numbers in this assay, from the lowest: compounds 1, 3 and 4 (each within the scatter of the next, the first and the last beyond it). At a limit, above all of these: compound 2.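

In this assay, hydrogen in place of nitro on the aromatic carbon para to a large group gives an at least 1.8-fold lower number from compound 2 to compound 4 (0.26 log units; that floor lies within the scatter). On this core, a compound without the nitro group thus reads as a number, with compound 4 at 53800 nM. The true size of the step stays open, because compound 2 stands at a limit of the assay: the limit of > 100000 nM in this assay, at which 1 of the 4 values shown sits.

The compounds shown leave open how an amine or a carboxylic acid at this position would read on this core.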